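A Side-Chain Swap and Its Expected Effect on Potency

The source may report more compounds than this note shows. Statements on the series, on what has been measured and on what is new or still open speak of the compounds shown alone.

Measured compounds:
Compound 1 `CC[C@H](C)[C@H](NC(=O)/C=C/c1ccc(C(F)(F)F)cc1)C(=O)OC`: 178 nM
Compound 2 `CC[C@H](C)[C@H](NC(=O)/C=C/c1ccc(F)cc1)C(=O)OC`: 421 nM

For the measured compounds named here, in an assay on isolated protein for inhibition of Nitric oxide synthase, inducible (Homo sapiens), with a stated time of 1 h (on this read-out higher numbers stand for weaker inhibition and lower numbers for stronger inhibition), compound 1 gives 178 nM, the lowest of the two numbers; compound 2 gives 421 nM, and the only measured step, a 2.4-fold higher number from compound 1 to compound 2 (0.37 log units; beyond the scatter), concerns the aromatic substituent, not the side chain. Compound 3 `COC(=O)[C@H](CC(C)C)NC(=O)/C=C/c1ccc(C(F)(F)F)cc1` differs from compound 1 by isobutyl in place of sec-butyl on a saturated chain carbon bound to an amide-type nitrogen and a carbonyl carbon. Going by the values given here, no measured step bears on this change, so the expectation rests on the side chains being alike in size and composition; the estimated step is a 1.4-fold higher number from compound 1 to compound 3 (0.15 log units; within the scatter), no change beyond the scatter. Compound 3 is therefore expected to give about 250 nM, between 90 nM and 700 nM.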

Compound 3, half-maximal inhibitory concentration: 195 nM
For compound 3 the middle estimate is 1.3-fold (0.11 log units) above the measured one; low and high end bracket the measured number.
By their numbers in this assay, from the lowest: compounds 1 and 3 (each within the scatter of the next); then compound 2.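

In this assay putting isobutyl in place of sec-butyl on this saturated chain carbon gives a 1.1-fold higher number from compound 1 to compound 3 (0.04 log units; within the scatter), so at this position the same atoms joined differently, with the defined stereocentre of sec-butyl gone, leave the number within the scatter. For the compounds shown here, the earlier pair varied only the aromatic substituent, so this is the first reading on the side chain. Nothing measured here offers a reason for this outcome.

As far as these compounds go, whether this position would accept a methyl group, a benzyl group or a side chain carrying an amine or a carboxylic acid stays open.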